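Thiophene carboxamide series: amide aryl exchange at compound 3

The compounds below may be only part of what the source reports. "The series", "measured", "known", "first", "only" and "open" are said of these compounds alone.

Measured compounds:
Compound 1 `NC(=O)c1c(NC(=O)c2ccc(C(F)(F)F)cc2)sc2c1CCN(Cc1ccccc1F)C2` — > 50000 nM
Compound 2 `COc1ccccc1C(=O)Nc1sc2c(c1C(N)=O)CCN(C(=S)Nc1ccccc1Cl)C2` — > 50000 nM

In a functional assay on HeLa cells (Homo sapiens) for antiproliferative activity, with a stated time of 24 h (a higher number here means a weaker inhibitor, a lower number a stronger inhibitor), compound 1 returns only a limit, > 50000 nM. In this assay compound 2 likewise returns only a limit, > 50000 nM. For the measured compounds named here, compound 2 therefore stands at the limit of the assay and not at a measured number; the one further value shown, that of compound 1, is a limit of the same kind. Going by the values given here, the evidence on the series so far is the limit of > 50000 nM in this assay, at which 2 of the 2 values shown sit.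

Compound 3 `NC(=O)c1c(NC(=O)c2ccc(C(F)(F)F)cc2)sc2c1CCN(C(=S)Nc1ccccc1Cl)C2` is not yet measured in this assay. It differs from compound 2 in one place: 4-(trifluoromethyl)phenyl in place of 2-methoxyphenyl on a carbonyl carbon. The same 4-(trifluoromethyl)phenyl amide is present in compound 1, which sits at the limit.

Among the compounds with values here, no step between measured compounds is known, so no size can be read from the data. Given that compound 1 and compound 2 both sit at the limit, the step from compound 2 to compound 3 is expected to be no larger than the scatter, estimated as a step that the limit leaves unreadable from compound 2 to compound 3, with a limit the most likely outcome. Compound 3 is estimated at 60000 nM in this assay, in the range 20000 nM to 200000 nM.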

Compound 3, half-maximal inhibitory concentration: 44000 nM
Estimate against measurement, compound 3: 1.4-fold (0.13 log units) above; low and high end bracket the measured number.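

In this assay compound 3 gives 44000 nM, the only value among the compounds shown that is a number and not a limit, so this combination of groups can be read in the assay. On a carbonyl carbon, 4-(trifluoromethyl)phenyl in place of 2-methoxyphenyl gives an at least 1.1-fold lower number from compound 2 to compound 3 (0.05 log units; that floor lies within the scatter), and on the amine nitrogen in a ring, the group of 10 heavy atoms in place of the group of 8 gives an at least 1.1-fold lower number from compound 1 to compound 3 (0.05 log units; that floor lies within the scatter). Each step is only a floor, so neither change is shown to act beyond the scatter, and the series as a whole remains close to the limit: the limit of > 50000 nM in this assay, at which 2 of the 3 values shown sit.

Going by these compounds, compound 1 and compound 2 carry limits and not numbers, so the true size of both steps stays open, and it is unknown whether either change contributes more than the other. Also open, on these data alone, is whether a carboxylic acid or an amine on the phenyl ring in place of trifluoromethyl, or a longer chain in place of the aryl group on the carbonyl carbon, would move the value clearly beyond the scatter from compound 3.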